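The source may hold more compounds than are shown below. What is called first, only, known or untested is meant among the compounds shown, and "the series" means these compounds.

Working notes on the series. In a functional assay on the whole organism (aorta) with Rattus norvegicus as the target (a lower number here means a smaller maximal response, a higher number a larger maximal response), compound 1 `CC1(C)C=C(n2ccccc2=O)c2cc(S(=O)(=O)N=[N+]=[N-])ccc2O1` gives 88.3%, and compound 2 `CNS(=O)(=O)c1ccc2c(c1)C(n1ccccc1=O)=CC(C)(C)O2` gives 85.8%; the step of a number 2.5 percentage points lower from compound 1 to compound 2 (within the scatter) lies within the scatter, so the two stand level. Compound 3 `CC1(C)C=C(n2ccccc2=O)c2cc(S(=O)(=O)Nc3ccccc3)ccc2O1` gives 63.6%; 82.5% (2 entries), two entries that differ from each other by more than the scatter (the several entries of compound 3 in this assay, 63.6%; 82.5% (2 entries)). Compound 4 `CC1(C)C=C(n2ccccc2=O)c2cc(S(=O)(=O)Oc3ccccc3)ccc2O1` carries phenoxy in place of azido on a sulfonyl sulfur. Among the measured compounds shown here, no measured step covers a phenoxy on the sulfonyl sulfur; the nearest indication is compound 3, whose two entries the several entries of compound 3 in this assay, 63.6%; 82.5% (2 entries) straddle the region near compound 1 and somewhat under it. A small downward step is therefore expected, a number 10.3 percentage points lower from compound 1 to compound 4 (beyond the scatter), though a result within the scatter would not surprise. Compound 4 is estimated at 78% in this assay, between 60% and 92%.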

Compound 4, largest response reached (Emax), in percent of the reference or control that the assay uses: 67.9%
The estimate for compound 4 lay 10.1 percentage points above the measured number; the measured number falls inside the stated range.
By their numbers in this assay, from the lowest: compound 4; then compounds 2 and 1 (each within the scatter of the next).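

In this assay, phenoxy gives a change on the sulfonyl sulfur that exceeds the scatter: a number 20.4 percentage points lower from compound 1 to compound 4 (beyond the scatter), and a number 17.9 percentage points lower from compound 2 to compound 4 (beyond the scatter). Azido and methylamino had stood level, so the group at this position can alter the maximal response. Compound 3 does not settle whether phenylamino behaves like phenoxy, as its entries lie far apart: the several entries of compound 3 in this assay, 63.6%; 82.5% (2 entries)

From the compounds shown here alone, it remains open whether the lower response goes with the oxygen link or with the aromatic ring. Methoxy and benzylamino on the sulfonyl sulfur would help separate these two features.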